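From fluoro to (3-fluorobenzyl)oxy on compound 1

A few compounds are considered here, and "the series" means these few. Any claim that something is new, unique, unknown or untested is made for them only; others in the source may bear on it.

Compound 1 `COc1cc2c(Nc3ccc(F)c(Cl)c3)ncnc2cc1OCCCn1ccnc1[N+](=O)[O-]` ends its chain in a 2-nitro-1H-imidazol-1-yl group. In a functional assay on A549 cells (Homo sapiens) for inhibition, read by sulforhodamine B assay, with a stated time of 72 h (on this read-out higher numbers stand for weaker inhibition and lower numbers for stronger inhibition), compound 1 gives 4310 nM on this measure. Compound 2 `COc1cc2c(Nc3ccc(F)c(Cl)c3)ncnc2cc1OCCCCCCn1ccnc1[N+](=O)[O-]` gives 6520 nM with a longer chain, and compound 3 `COc1cc2c(Nc3ccc(F)c(Cl)c3)ncnc2cc1OCCOCCn1ccnc1[N+](=O)[O-]` gives 7640 nM with an oxygen in its chain. Compound 1 therefore stands level with both relatives, as the steps show: a 1.5-fold higher number from compound 1 to compound 2 (0.18 log units; within the scatter) and a 1.8-fold higher number from compound 1 to compound 3 (0.25 log units; within the scatter) and finally a 1.2-fold higher number from compound 2 to compound 3 (0.07 log units; within the scatter) to complete the set.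

Compound 4 `COc1cc2c(Nc3ccc(OCc4cccc(F)c4)c(Cl)c3)ncnc2cc1OCCCn1ccnc1[N+](=O)[O-]` keeps the chain of compound 1 but changes another site: (3-fluorobenzyl)oxy in place of fluoro on an aromatic carbon in a single swap. This aromatic carbon is ortho to a chloro group. All three measured steps alter only the chain, so none bears directly on this swap, and the data offer no direction for it. No step beyond the scatter is therefore expected in this assay for now, though with little confidence. The expected change is a 1.1-fold lower number from compound 1 to compound 4 (0.03 log units; within the scatter) as an estimate. For compound 4 the estimated value is 4000 nM with an expected range from 1500 nM to 10000 nM in this measurement.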

Compound 4, half-maximal inhibitory concentration: 1520 nM
For compound 4 the middle estimate is 2.6-fold (0.42 log units) above the measured one, and the stated range covers the measured number.
By their numbers in this assay, from the lowest: compound 4; then compounds 1, 2 and 3 (each within the scatter of the next).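

Until now every step concerned the chain and stayed within the scatter. Within the data shown here, this swap, on the aromatic carbon ortho to a chloro group, is the first change to go beyond it, with a 2.8-fold lower number from compound 1 to compound 4 (0.45 log units; beyond the scatter) in this assay. The position therefore takes a far larger group, (3-fluorobenzyl)oxy with its nine heavy atoms and six-membered aromatic ring in place of a single fluoro, and inhibition grows modestly stronger rather than being lost, although no measured evidence explains this gain.

Compound 4 brings in the oxygen, the ring and the ring's fluorine together, so a plain benzyloxy or a small methoxy group on this carbon would be needed to tell their shares apart. On these data alone, whether the gain carries over to the longer chain of compound 2 or the oxygen-containing chain of compound 3 also remains open.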